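The source may hold more compounds than are shown below. What is called first, only, known or untested is meant among the compounds shown, and "the series" means these compounds.

Of the compounds shown here, three have been measured in a functional assay on A549 cells (Homo sapiens) for cytotoxicity, read by MTT assay, with a stated time of 48 h; a lower number here means a stronger inhibitor, a higher number a weaker inhibitor. Compound 1 `CCOC(=O)c1c(-c2c(Cl)c3ccccc3oc2=O)nn(-c2ccc(Br)cc2)c1C(=O)OCC` gives 30000 nM in this assay. Compound 2 `COC(=O)c1c(-c2cc3ccccc3oc2=O)nn(-c2ccccc2)c1C(=O)OC` gives 28000 nM, and compound 3 `COC(=O)c1c(-c2cc3ccccc3oc2=O)nn(-c2cccc(C)c2)c1C(=O)OC` gives 51000 nM. These three numbers lie close together: the step of a 1.8-fold higher number from compound 2 to compound 3 (0.26 log units; within the scatter) is within the scatter, and the number for compound 3 also differs from the number for compound 1 by less than the scatter, so none of the three can be told apart on the evidence so far.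

Compound 4 `COC(=O)c1c(-c2cc3ccccc3oc2=O)nn(-c2cccc(Cl)c2)c1C(=O)OC` has not yet been measured. It differs from compound 3 in one place: chloro in place of methyl on an aromatic carbon of a six-membered aromatic ring of carbon only, meta to a large group. Within the data shown here, no measured pair shows chloro against methyl on this ring. Among the measured compounds shown here, the only measured step that touches this ring, a 1.8-fold higher number from compound 2 to compound 3 (0.26 log units; within the scatter), put methyl in place of hydrogen and stayed within the scatter, which suggests that a small change on this ring has so far left the number in this assay roughly where it was. The step of a 1.1-fold lower number from compound 3 to compound 4 (0.05 log units; within the scatter) is therefore expected to be small, with no clear direction beyond the scatter. Compound 4 is estimated at 45000 nM, with a range from 20000 nM to 100000 nM.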

Compound 4, half-maximal inhibitory concentration: 30000 nM
Compound 4: the middle estimate sits 1.5-fold (0.18 log units) above what was measured; measured number inside the range.
By their numbers in this assay, from the lowest: compounds 2, 1, 4 and 3 (each within the scatter of the next).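

In this assay the change from 3-methylphenyl to 3-chlorophenyl gives a 1.7-fold lower number from compound 3 to compound 4 (0.23 log units; within the scatter), so swapping one single-atom group for another at this place does not separate the two compounds. The comparison with hydrogen at the same place gives a 1.1-fold higher number from compound 2 to compound 4 (0.03 log units; within the scatter), and together with the earlier methyl step this means hydrogen, methyl and chloro on this aromatic carbon, meta to a large group, all read within the scatter of one another, which a single step could not show. No measurement of any property of these groups accompanies these numbers, so nothing here accounts for this result.

The compounds shown leave open whether a group of another kind at this place, such as an amine, a carboxylic acid or a longer chain, would give a number beyond the scatter of these three. They also leave open whether hydrogen, methyl and chloro would read alike at this place on the core of compound 1, which differs from compound 2 in more than one place.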